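The compounds below may be only part of what the source reports. "The series", "measured", "known", "first", "only" and "open" are said of these compounds alone.

In a functional assay on HeLa cells (Homo sapiens) for antiproliferative activity, read by MTT assay, with a stated time of 72 h (on this read-out higher numbers stand for weaker inhibition and lower numbers for stronger inhibition), compound 1 `COc1ccc(-c2c(C(=O)c3cc(OC)c(OC)c(OC)c3)sc3ccccc23)c(OC)c1` gives 3900 nM and compound 2 `CCOc1ccc(-c2c(C(=O)c3cc(OC)c(OC)c(OC)c3)sc3ccccc23)cc1` gives 3000 nM. Among the compounds with values here, the only measured step is a 1.3-fold lower number from compound 1 to compound 2 (0.11 log units; within the scatter), so compound 2 stands level with its one neighbour.

Compound 3 `COc1ccc(Nc2c(C(=O)c3cc(OC)c(OC)c(OC)c3)sc3ccccc23)cc1` carries (4-methoxyphenyl)amino in place of 4-ethoxyphenyl, on an aromatic carbon of a five-membered aromatic ring with 1 sulfur: (4-methoxyphenyl)amino in place of 4-ethoxyphenyl on an aromatic carbon.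

That one measured step bears on this change only in part. Within the data shown here, it exchanges one aryl group for another, whereas compound 3 brings in an amino link that no measured compound has. Among the measured compounds shown here, the data therefore hold no step for that link, and they give no basis for a direction. For the measured compounds named here, with the single reference step being a 1.3-fold lower number from compound 1 to compound 2 (0.11 log units; within the scatter), no shift beyond the scatter is expected, although the uncertainty is wide. The expected step in this assay is a 1.2-fold lower number from compound 2 to compound 3 (0.08 log units; within the scatter). The estimate for compound 3 is 2500 nM, with an expected range of 500 nM to 10000 nM.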

Compound 3, half-maximal inhibitory concentration: 7700 nM
The estimate for compound 3 lay 3.1-fold (0.49 log units) below the measured number, within the range that was stated.
By their numbers in this assay, from the lowest: compounds 2, 1 and 3 (each within the scatter of the next, the first and the last beyond it).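

In this assay, within the data shown here, the swap of 4-ethoxyphenyl for (4-methoxyphenyl)amino at this position gives a 2.6-fold higher number from compound 2 to compound 3 (0.41 log units; beyond the scatter) and is the first step to lie beyond the scatter. Against 2,4-dimethoxyphenyl the same amino-linked group gives a 2.0-fold higher number from compound 1 to compound 3 (0.30 log units; within the scatter) and leaves compound 1 and compound 3 unseparated, so the weakening is resolved against only one of the two aryl groups. The entering group brings a hydrogen-bond donor that the leaving group lacks, but no measurement shown ties the step to that difference or to anything else.

Going by these compounds, the step from compound 2 to compound 3 changes both the link to the core and the alkoxy group on the phenyl ring, so the share of each remains open. Also open, on these data alone, is whether a (4-ethoxyphenyl)amino group would separate these two changes, and whether a methylene or ether oxygen link in place of the amine would track the directly attached aryl groups or the amino-linked one.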